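The compounds below may be only part of what the source reports. "The series", "measured", "known", "first", "only" and "open" are said of these compounds alone.

Working notes on the series. Compound 1 `Cc1nn(C)c2c1C(c1ccccc1)=NCCN2` and compound 2 `Cc1nn(C)c2c1C(c1ccc(Cl)c(Cl)c1)=NCCN2` share one core and differ only in the substitution of a six-membered aromatic ring of carbon only. In a functional assay on the whole organism for positive allosteric modulation, with Rattus norvegicus as the target (on this read-out higher numbers stand for an effect only at larger amounts of compound and lower numbers for an effect already at smaller amounts), compound 1 gives 2.5 mg/kg. In this assay compound 2 gives 2.5 mg/kg. Compound 2 thus stands level with compound 1 at the digits reported; the two readings sit within the scatter of each other, so no order between them is drawn. Among the measured compounds shown here, no step between these two measured compounds is counted; only their two values are set side by side.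

Compound 3 `Cc1nn(C)c2c1C(c1ccc(Cl)cc1)=NCCN2` is the unmeasured member. It differs from compound 2 by hydrogen in place of chloro on an aromatic carbon. Because compound 2 at 2.5 mg/kg and compound 1 at 2.5 mg/kg read the same within the scatter despite differing by two chloro groups, no step beyond the scatter is expected in this assay on going from compound 2 to compound 3. The expected step is no change at the digits printed from compound 2 to compound 3 (within the scatter). Compound 3 is estimated to give 2.5 mg/kg in this assay, with a range from 1.2 mg/kg to 5 mg/kg.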

Compound 3, minimum effective dose: 2.5 mg/kg
Estimate against measurement, compound 3: no gap at the digits printed, within the range that was stated.
By their numbers in this assay, from the lowest: compounds 1, 2 and 3 (each within the scatter of the next).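

The chloro group that sits ortho to a chloro group and meta to a large group can now be read on its own: in this assay, hydrogen in its place gives no change at the digits printed from compound 2 to compound 3 (within the scatter). The other single change on the same ring, chloro in place of hydrogen on an aromatic carbon, gives no change at the digits printed from compound 1 to compound 3 (within the scatter), so neither single step on this ring moves the reading beyond the scatter, whereas the earlier pair showed only the two chloro groups taken together. No measurement at hand offers any account of these readings.

The ring in the compounds shown carries only hydrogen or chloro, so the tolerance seen here extends to these two substituents alone, and what a methoxy group, an amine or a carboxylic acid at the same aromatic carbon would do in this assay remains open. Also open, on these data alone, is whether any change on this ring can shift the minimum effective dose beyond the scatter, or whether other parts of the shared core, such as its two methyl groups, are the places where such a shift could be found.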